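The compounds below may be only part of what the source reports. "The series", "measured", "known", "first", "only" and "open" are said of these compounds alone.

Three compounds share one core and differ only in the acid-bearing tail attached to it: compound 1 `O=C(O)[C@@H]1CCCN1C(=O)CN(c1nc(Cl)nc2[nH]cnc12)C1CC1`, compound 2 `O=C(CN(c1nc(Cl)nc2[nH]cnc12)C1CC1)NCC(=O)OCc1ccccc1` and compound 3 `O=C(O)CC[C@H](NC(=O)CN(c1nc(Cl)nc2[nH]cnc12)C1CC1)C(=O)O`. In a functional assay on the whole organism (Tail, strain ICR) with Mus musculus as the target, in the tail flick test, with a stated time of 120 min, at a dose of 25 umol/kg by the oral route (on this read-out lower numbers stand for a weaker effect and higher numbers for a stronger effect at the one dose given), compound 3 gives 30.1%, the highest of the three numbers, yet both others fall within the usual scatter of it: compound 1 gives 23.6%, and compound 2 gives 21.7%, so no ordering among them can be claimed. Compound 4 `NC(=O)C[C@H](NC(=O)CN(c1nc(Cl)nc2[nH]cnc12)C1CC1)C(=O)O` has not been measured yet. It differs from compound 3 by carbamoyl in place of carboxymethyl on a saturated chain carbon, two bonds along the chain from an amide-type nitrogen and a carbonyl carbon. Nothing measured here shows how such a swap acts, so the step expected from this change is a number 2.1 percentage points lower from compound 3 to compound 4 (within the scatter), none beyond the scatter. Compound 4 is therefore estimated at 28%, with a range from 15% to 41%.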

Compound 4, a percentage reported as activity, at one dose (the size of the read-out at that dose, not a potency): 17%
For compound 4 the middle estimate is 11 percentage points above the measured one; low and high end bracket the measured number.
By their numbers in this assay, from the lowest: compounds 4, 2, 1 and 3 (each within the scatter of the next, the first and the last beyond it).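

Within this assay carbamoyl in place of carboxymethyl on a saturated chain carbon, two bonds along the chain from an amide-type nitrogen and a carbonyl carbon, gives a number 13.1 percentage points lower from compound 3 to compound 4 (beyond the scatter) and so shows that this position can register a change that compounds 1, 2 and 3 never showed among themselves. The swap also takes the group from 4 heavy atoms to 3, so a new end group and a smaller size arrive together. Nothing available explains the step. From the compounds shown here alone, whether a longer chain ending in carbamoyl, or an amine at this place, would restore the effect of compound 3 stays open.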